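The source may hold more compounds than are shown below. What is called first, only, known or untested is meant among the compounds shown, and "the series" means these compounds.

Of the compounds shown here, three from this study have been tested in a functional assay on HeLa cells (Homo sapiens) for cytotoxicity, read by WST assay, with a stated time of 48 h; a higher number here means a weaker inhibitor, a lower number a stronger inhibitor. Compound 1 `COC[C@H](C(C)C)C(c1ccc(O)c(OC)c1)c1ccc(O)c(OC)c1` gives 76000 nM in this assay. Compound 2 `COc1cc(C(c2ccc(O)c(OC)c2)[C@H](CF)C(C)C)ccc1O` gives 19000 nM in this assay. Among the compounds with values here, the one measured step between them is a 4.0-fold lower number from compound 1 to compound 2 (0.60 log units; beyond the scatter), and it is the only step in this set whose size is known. Compound 3 `COc1ccc(C(c2ccc(OC)c(OC)c2)[C@@H](C)[C@@H](C)CO)cc1OC` reaches only a limit of the assay, > 100000 nM, so no number is known for it. Compound 3 therefore stands at the limit of > 100000 nM in this assay, at which 1 of the 3 values shown sits, rather than at a measured value. Compound 4 `COc1ccc(C(c2ccc(OC)c(OC)c2)[C@H](C)[C@H](C)CO)cc1OC` has not yet been measured in this assay. It differs from compound 3 only in configuration: the two compounds have the same atoms and bonds and differ only in configuration as drawn: 2 of 2 stereo elements differ (all stereocentres are inverted: mirror images); a stereocentre at a saturated chain carbon is drawn R in compound 3 and S in compound 4; a stereocentre at a saturated chain carbon is drawn R in compound 3 and S in compound 4. No measured step involves a change of configuration, and the step from compound 1 to compound 2 is a change of a different kind, so nothing shown speaks directly to the size or direction of the step from compound 3 to compound 4. With no comparison of mirror images among the measured compounds, the expected step is a number no higher from compound 3 to compound 4 (the limit leaves the size open), that is, none beyond the scatter. Compound 4 is therefore estimated at 100000 nM, with a range from 40000 nM to 300000 nM, and it may well again return only a limit in this assay.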

Compound 4, half-maximal inhibitory concentration: > 100000 nM
Compound 4: no number, only a limit (the forecaster's own chance of this, stated with the estimate: 65%); the middle value lies on the limit itself.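

The step from compound 3 to compound 4 cannot be read, as neither has a number and both stop at a limit: the limit of > 100000 nM in this assay, at which 2 of the 4 values shown sit. The compounds shown leave open whether either of these mirror images is a stronger inhibitor than the other in this assay, and so whether configuration matters here at all.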